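A few compounds are considered here, and "the series" means these few. Any claim that something is new, unique, unknown or untested is made for them only; others in the source may bear on it.

Of the compounds shown here, two sharing one core have been measured in an ADME assay on J774 cells (Mus musculus) for cytotoxicity, read by MTT assay, with a stated time of 48 h, tested at 150 ug/mL; on this read-out lower numbers stand for a stronger effect and higher numbers for a weaker effect at the one concentration tested. Compound 1 `O=C(N/N=C/c1cccc(F)c1)c1cnccn1` gives 40%, the lowest of the two numbers, while compound 2 `CCOc1ccc(/C=N/NC(=O)c2cnccn2)cc1` gives 100%, a number that lies beyond the scatter above it. For the measured compounds named here, no two measured compounds differ in only one place, so no step has yet been measured. Compound 3 `O=C(N/N=C/c1cccc([N+](=O)[O-])c1)c1cnccn1` differs from compound 1 by nitro in place of fluoro on an aromatic carbon. In this assay the step expected is a number 15 percentage points higher from compound 1 to compound 3 (beyond the scatter), upward, though it may not exceed the scatter. Compound 3 is therefore expected to give about 55%, between 25% and 85%.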

Compound 3, a percentage reported as activity, at one concentration (the size of the read-out at that concentration, not a potency): 76%
For compound 3 the middle estimate is 21 percentage points below the measured one, within the range that was stated.
By their numbers in this assay, from the lowest: compound 1; then compound 3; then compound 2.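

In this assay, nitro in place of fluoro on an aromatic carbon, meta to a large group, gives a number 36 percentage points higher from compound 1 to compound 3 (beyond the scatter) with the rest of the structure unchanged. This single exchange shows that the read-out depends on the group at this position, and that the change is large rather than lost in the scatter. No measurement at hand explains this step. The compounds shown leave open how an amine or a carboxylic acid at this same position would read, and whether a chlorine would stay closer to fluoro or to nitro.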